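The compounds below may be only part of what the source reports. "The series", "measured", "known", "first", "only" and "open" are said of these compounds alone.

Measured in a functional assay on SK-OV-3 cells (Homo sapiens) for inhibition, read by CCK-8 assay, with a stated time of 70 h; on this read-out higher numbers stand for weaker inhibition and lower numbers for stronger inhibition:
Compound 1 `Clc1ccc(COc2ccc(OCCOCCNC3CCCC3)cc2)cc1`: 7670 nM
Compound 2 `Nc1ccc(COc2ccc(OCCOCCNC3CCCC3)cc2)cc1`: 31700 nM
Compound 3 `COC(=O)c1cccc(COc2ccc(OCCOCCNC3CCCC3)cc2)c1`: 45500 nM

Compound 3 shares the weak end of this small set with compound 2, and the step between them is a 1.4-fold higher number from compound 2 to compound 3 (0.16 log units; within the scatter). Compound 1 stands apart from both, with a 4.1-fold higher number from compound 1 to compound 2 (0.62 log units; beyond the scatter) and a 5.9-fold higher number from compound 1 to compound 3 (0.77 log units; beyond the scatter).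

Compound 4 `O=[N+]([O-])c1cccc(COc2ccc(OCCOCCNC3CCCC3)cc2)c1` keeps the shared core and carries nitro in place of methoxycarbonyl on an aromatic carbon, meta to a large group (nitro in place of methoxycarbonyl on an aromatic carbon). Within the data shown here, no measured step makes this exact exchange, so the estimate rests on the other changes of the group on this aromatic ring. These span a modest range, from a 1.4-fold higher number from compound 2 to compound 3 (0.16 log units; within the scatter) up to a 5.9-fold higher number from compound 1 to compound 3 (0.77 log units; beyond the scatter). The exchange in compound 4 leaves the remainder of compound 3 untouched, and the data do not show how nitro itself behaves. A step beyond the scatter is therefore not expected in this assay, though a slight move toward lower numbers seems more likely than a move toward higher ones. The step estimated here is a 1.6-fold lower number from compound 3 to compound 4 (0.21 log units; within the scatter). For compound 4 the expected value is 28000 nM, with an estimated range of 10000 nM to 65000 nM.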

Compound 4, half-maximal inhibitory concentration: 15400 nM
Beside the measured number, compound 4's estimate is 1.8-fold (0.26 log units) above it, and the stated range covers the measured number.
By their numbers in this assay, from the lowest: compounds 1 and 4 (each within the scatter of the next); then compounds 2 and 3 (each within the scatter of the next).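

In this assay, nitro in place of methoxycarbonyl on an aromatic carbon, meta to a large group, gives a 3.0-fold lower number from compound 3 to compound 4 (0.47 log units; beyond the scatter), so the number at this place depends on the group it carries, which compound 3 alone could not show. The 3-nitrophenyl compound also separates from the 4-aminophenyl compound, with a 2.1-fold lower number from compound 2 to compound 4 (0.31 log units; beyond the scatter), while a 2.0-fold higher number from compound 1 to compound 4 (0.30 log units; within the scatter) puts it level with the 4-chlorophenyl compound, so the high number of compound 3 is not tied to this place on the ring alone. Nothing at hand explains why these two groups differ in this assay.

The compounds shown leave open how far the group and its place on the ring act apart, since each of the four carries a different group. They also leave open whether a nitrile, a carboxylic acid or an amine at this same place would stay with nitro or fall in with methoxycarbonyl.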